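Carbamate chain growth on the shared core

This account rests on a few compounds, and the source may have more. Where it says the series, first, only, none or still open, it means among the compounds named here.

Compound 2 `CC(C)COC(=O)N1CCC(Oc2ncnc3c2CCN3c2ccc(S(C)(=O)=O)cc2F)CC1` stands lowest of the two numbers in a functional assay on CHO-K1 cells with Glucose-dependent insulinotropic receptor (Homo sapiens) as the target, read by a luciferase reporter, with a stated time of 5 h (on this read-out higher numbers stand for larger maximal responses and lower numbers for smaller maximal responses), giving 94%; compound 1 `COC(=O)N1CCC(Oc2ncnc3c2CCN3c2ccc(S(C)(=O)=O)cc2F)CC1` gives 119%. Going by the values given here, the one measured step bearing on the next change is a number 25 percentage points lower from compound 1 to compound 2 (beyond the scatter), a modest loss when the carbamate chain is lengthened. Compound 3 `CC(C)(C)COC(=O)N1CCC(Oc2ncnc3c2CCN3c2ccc(S(C)(=O)=O)cc2F)CC1` differs from compound 2 by methyl in place of hydrogen on a saturated chain carbon bound to three saturated chain carbons. Growing the chain once more is expected to cost little, so a step of a number 8 percentage points lower from compound 2 to compound 3 (within the scatter) is expected, at or barely beyond the scatter. Compound 3 is therefore estimated at 86%, within 68% to 104%.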

Compound 3, largest response reached (reported as percent of maximum), in percent of the reference or control that the assay uses: 80%
The estimate for compound 3 lay 6 percentage points above the measured number; the range from low to high includes it.
By their numbers in this assay, from the lowest: compound 3; then compound 2; then compound 1.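

Methyl in place of hydrogen on this saturated chain carbon, isobutyl to neopentyl, still gives a number 14 percentage points lower from compound 2 to compound 3 (beyond the scatter) in this assay so the loss continues past the first chain growth. Tert-butyl in place of hydrogen on the saturated chain carbon bound to an oxygen next to a carbonyl group gives a number 39 percentage points lower from compound 1 to compound 3 (beyond the scatter) and all three compounds fall in one order, with none going against it. Nothing measured here accounts for this decline.

Open, on these data alone, is how a cyclopropylmethyl group or a longer chain carrying an amine would read on this carbamate.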